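The source may hold more compounds than are shown below. What is called first, only, known or untested is meant among the compounds shown, and "the series" means these compounds.

The series shares the core of compound 1 `CC1(c2ccccc2)CC(=O)N(CC(=O)N2CCN(c3ccccc3F)CC2)C1=O`, which in a functional assay on the whole organism (strain CD-1) with Mus musculus as the target, in the maximal electroshock model, with a stated time of 2 h (on this read-out higher numbers stand for an effect only at larger amounts of compound and lower numbers for an effect already at smaller amounts), is reported as "not active" (no number reported). Compound 2 `Cc1cccc(N2CCN(C(=O)CN3C(=O)CC(C)(c4ccccc4)C3=O)CC2)c1` in this assay gives 300 mg/kg. Compound 3 `CC1(c2ccccc2)CC(=O)N(CC(=O)N2CCN(c3ccccc3)CC2)C1=O` is likewise reported as "not active" (no number reported) in this assay, so no number stands for it, and one further compound in the set also lacks a number; only compound 2 carries a value at all. The step from compound 3 to compound 4 `CC1(c2ccccc2)CC(=O)N(CC(=O)N2CCN(c3ccccc3Cl)CC2)C1=O` is chloro in place of hydrogen on an aromatic carbon. No measured pair in the set matches this change, so no direction can be drawn from the data; on the numbers shown, no effect beyond the scatter is expected, and a reading without a number remains likely. Compound 4 is expected to give about 300 mg/kg in this assay, within the range 100 mg/kg to 600 mg/kg.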

Compound 4, minimum effective dose: "not active" (no number reported)
Compound 4: no number reported; there is nothing to compare the estimate with.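

Compound 3 and compound 4 both lack a number, so no step can be read between them, and nothing measured here bears on this result. The compounds shown leave open whether chloro in place of hydrogen shifts the effective dose at all.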